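The compounds below may be only part of what the source reports. "The series", "measured", "known", "first", "only" and "open" are said of these compounds alone.

Measured compounds in a functional assay on the whole organism with Canis familiaris (Canis lupus familiaris) as the target; on this read-out lower numbers stand for an effect already at smaller amounts and higher numbers for an effect only at larger amounts of compound:

compound 1, `C/C=C(C)/C=C/[C@](C)(O)C/C=C/[C@H]1[C@H](O)CC(=O)[C@@H]1CC/C=C\CCC(=O)OC`: 0.000003 mg/kg
compound 2, `C/C=C/C=C/[C@](C)(O)C/C=C/[C@H]1[C@H](O)CC(=O)[C@@H]1CC/C=C\CCC(=O)OC`: 0.00003 mg/kg
compound 3, `C/C=C\C=C\[C@](C)(O)C/C=C/[C@H]1[C@H](O)CC(=O)[C@@H]1CC/C=C\CCC(=O)OC`: 0.0000099 mg/kg

Compound 3 stands second highest of the three numbers; its nearest neighbour is compound 2, reached by a 3.0-fold lower number from compound 2 to compound 3 (0.48 log units; beyond the scatter), and its furthest is compound 1, reached by a 3.3-fold higher number from compound 1 to compound 3 (0.52 log units; beyond the scatter). Compound 4, `C=C(C)/C=C/[C@](C)(O)C/C=C/[C@H]1[C@H](O)CC(=O)[C@@H]1CC/C=C\CCC(=O)OC`, is not yet measured. It differs from compound 3 as follows: 1-methylethenyl in place of prop-1-en-1-yl on a double-bonded chain carbon bound to a double-bonded chain carbon.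

Among the compounds with values here, three measured steps touch the same side chain. The step of a 10-fold higher number from compound 1 to compound 2 (1.00 log units; beyond the scatter) shows that a methyl on the chain matters; the step of a 3.3-fold higher number from compound 1 to compound 3 (0.52 log units; beyond the scatter) shows that shortening the side chain by moving from 1-methylprop-1-en-1-yl to prop-1-en-1-yl also costs; and a 3.0-fold lower number from compound 2 to compound 3 (0.48 log units; beyond the scatter) rests on (the fact that compounds 2 and 3 differ only in the configuration as drawn). None of them reproduces the exchange to 1-methylethenyl, which keeps a methyl at the inner carbon but drops the outer carbon. A modest rise in the number is therefore expected, with wide uncertainty, as a 2.0-fold higher number from compound 3 to compound 4 (0.31 log units; beyond the scatter). Compound 4 is estimated at 0.00002 mg/kg in this assay, within 0.000004 mg/kg to 0.0001 mg/kg.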

Compound 4, dose for half-maximal effect: 0.00002 mg/kg
For compound 4 middle estimate and measured number coincide at the digits printed; low and high end bracket the measured number.
By their numbers in this assay, from the lowest: compound 1; then compound 3; then compounds 4 and 2 (each within the scatter of the next).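

In this assay, 1-methylethenyl in place of prop-1-en-1-yl gives a 2.0-fold higher number from compound 3 to compound 4 (0.31 log units; beyond the scatter), so the two isomeric three-carbon groups are not interchangeable at this place when set against the Z-drawn partner. Against the E-drawn partner the same exchange gives a 1.5-fold lower number from compound 2 to compound 4 (0.18 log units; within the scatter), and the branched group cannot be told apart from the straight one; the two reference points for this exchange differ in a single feature: the fact that compounds 2 and 3 differ only in the configuration as drawn. The methyl branch alone does not hold the level of compound 1, as 1-methylethenyl in place of 1-methylprop-1-en-1-yl gives a 6.7-fold higher number from compound 1 to compound 4 (0.82 log units; beyond the scatter).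

Open, as far as these compounds go, is how a saturated propyl group, or a longer chain such as 1-methylbut-1-en-1-yl, would read at this place. The compounds shown also leave open whether a polar end, such as a carboxylic acid or an amine, is tolerated there.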